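The compounds below may be only part of what the source reports. "The series", "measured", "known", "first", "only" and "open" are said of these compounds alone.

Compound 1 `COc1ccc2ncc(S(=O)(=O)c3ccc(Cl)cc3)c(N3CCC(C)CC3)c2c1` is the starting point of this account. In an assay on isolated protein for displacement of a labelled ligand from metabotropic glutamate receptor 5 (Homo sapiens), with a stated time of 60 min, tested at 1 uM (a lower number here means less inhibition, a higher number more inhibition at the concentration tested (going by the name of the read-out)), compound 1 gives 91%, which puts it second highest of the three measured compounds. Compound 2 `Cc1ccc(S(=O)(=O)c2cnc3ccc(F)cc3c2N2CCC(C)CC2)cc1C` gives 92% in this assay, a number that lies within the scatter of compound 1. Compound 3 `CC1CCN(c2c(S(=O)(=O)c3ccc(Cl)cc3)cnc3ccc(F)cc23)CC1` gives 80% in this assay, and the two steps that lead to it are a number 11 percentage points lower from compound 1 to compound 3 (beyond the scatter) and a number 12 percentage points lower from compound 2 to compound 3 (beyond the scatter).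

Compound 4 `COc1cccc(S(=O)(=O)c2cnc3ccc(OC)cc3c2N2CCC(C)CC2)c1` differs from compound 1 by 3-methoxyphenyl in place of 4-chlorophenyl on a sulfonyl sulfur. Going by the values given here, of the measured steps, only the one from compound 2 to compound 3 concerns the group on the sulfonyl sulfur, and it shows that exchanging that group can move the number by a number 12 percentage points lower from compound 2 to compound 3 (beyond the scatter). Among the compounds with values here, no measured compound carries 3-methoxyphenyl there, so the direction is not known; the data only show that such an exchange on the sulfonyl sulfur tends to shift the number by a modest amount. Compound 4 is therefore expected to give about 85% in this assay, with a range from 65% to 97%, corresponding to an expected step of a number 6 percentage points lower from compound 1 to compound 4 (within the scatter).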

Compound 4, a percentage reported as inhibition, at one concentration (the size of the read-out at that concentration, not a potency): 0%
Compound 4: the middle estimate sits 85 percentage points above what was measured, outside the stated range (below it).
By their numbers in this assay, from the lowest: compound 4; then compound 3; then compounds 1 and 2 (each within the scatter of the next).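

Going by these compounds alone, the sulfonyl sulfur proves far more sensitive than the earlier compounds indicated: in this assay, 3-methoxyphenyl in place of 4-chlorophenyl gives a number 91 percentage points lower from compound 1 to compound 4 (beyond the scatter). Within the data shown here, the only earlier exchange at this place gave a number 12 percentage points lower from compound 2 to compound 3 (beyond the scatter), so a change on the sulfonyl sulfur is not confined to a modest shift and can abolish the inhibition seen at the concentration tested. Nothing among the available data accounts for this collapse.

The compounds shown cannot separate the loss of the chlorine from the arrival of the methoxy group, as both happen in the same step. Going by these compounds, it also remains open how an unsubstituted phenyl group on the sulfonyl sulfur would stand on the core of compound 1.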